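Swapping an ether for an ester on a naphthoquinone scaffold

The compounds below may be only part of what the source reports. "The series", "measured", "known", "first", "only" and "open" are said of these compounds alone.

Measured compounds in a functional assay on DU-145 cells (Homo sapiens) for cytotoxicity, read by MTT assay; on this read-out lower numbers stand for stronger inhibition and higher numbers for weaker inhibition:
compound 1, `CCCCC(O)CC(=O)O[C@H](CC=C(C)C)C1=CC(=O)c2c(O)ccc(O)c2C1=O`, 45300 nM
compound 2, `CC(C)=CC[C@@H](OC[C@H](C)O)C1=CC(=O)c2c(O)ccc(O)c2C1=O`, 24500 nM

Compound 2 and compound 1 sit within the scatter of each other, with a 1.8-fold lower number from compound 1 to compound 2 (0.27 log units; within the scatter). Compound 3, `CC(C)=CC[C@@H](OC(=O)C1CCCOC1)C1=CC(=O)c2c(O)ccc(O)c2C1=O`, carries (oxan-3-yl)carbonyl in place of 2-hydroxypropyl on an oxygen on a saturated carbon. Going by the values given here, the only step that bears on it is the one from compound 1 to compound 2, which was within the scatter, so the reverse move back to a carbonyl-linked group is expected to give no shift beyond the scatter. Compound 3 is therefore expected to give 35000 nM, between 12000 nM and 100000 nM, in this assay. This would be an expected 1.4-fold higher number from compound 2 to compound 3 (0.15 log units; within the scatter).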

Compound 3, half-maximal inhibitory concentration: 29700 nM
Compound 3: middle estimate off by 1.2-fold (0.07 log units), on the high side; measured number inside the range.
By their numbers in this assay, from the lowest: compounds 2, 3 and 1 (each within the scatter of the next).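

In this assay, a group with a six-membered ring and no hydrogen-bond donor on this oxygen still leaves the change within the scatter: a 1.2-fold higher number from compound 2 to compound 3 (0.08 log units; within the scatter). Replacing 2-hydroxyhexyl with oxan-3-yl on the carbonyl carbon also stays within it, a 1.5-fold lower number from compound 1 to compound 3 (0.18 log units; within the scatter), so these side groups do not separate the three compounds. Nothing measured here offers an explanation for this result. From the compounds shown here alone, whether an amine or a carboxylic acid in this place would shift the number beyond the scatter remains open.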